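This account rests on a few compounds, and the source may have more. Where it says the series, first, only, none or still open, it means among the compounds named here.

Measured so far in a functional assay on PC-3 cells (Homo sapiens) for inhibition; on this read-out lower numbers stand for stronger inhibition of growth and higher numbers for weaker inhibition of growth:

- compound 1 `Cc1cccc(NC(=O)COc2ccc(/C=C3\SC(=O)NC3=O)cc2)n1`: 58300 nM
- compound 2 `O=C(COc1ccc(/C=C2\SC(=O)NC2=O)cc1)Nc1cccc([N+](=O)[O-])c1`: > 100000 nM, which is a limit of the assay and not a number
- compound 3 `O=C(COc1ccc(/C=C2\SC(=O)NC2=O)cc1)Nc1ccc(F)cc1F`: > 100000 nM, likewise a limit of the assay

All three share one core and differ only in the aromatic ring attached to the amide-type nitrogen. Compound 2 stands at the upper edge of what this assay reports, namely (the limit of > 100000 nM in this assay, at which 2 of the 3 values shown sit); its true value could lie anywhere beyond that edge. The step of an at least 1.7-fold higher number from compound 1 to compound 2 (0.23 log units; that floor lies within the scatter) is therefore only a floor, and the same holds for an at least 1.7-fold higher number from compound 1 to compound 3 (0.23 log units; that floor lies within the scatter). The step that the two limits leave unreadable from compound 2 to compound 3 cannot be read at all, since both of its ends are limits.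

Compound 4 `O=C(COc1ccc(/C=C2\SC(=O)NC2=O)cc1)Nc1c(F)cc(Br)cc1F` has not yet been measured in this assay. It differs from compound 2 as follows: 4-bromo-2,6-difluorophenyl in place of 3-nitrophenyl on an amide-type nitrogen. No readable step among the measured compounds links two rings of this kind, so there is no ground for expecting a shift beyond the scatter in either direction. Of the three measured compounds, only compound 1 gave a number; compounds 2 and 3 gave limits.

Compound 4 is expected to come out near 100000 nM, with a likely range from 30000 nM to 300000 nM. That estimate corresponds to an expected step of a number no higher from compound 2 to compound 4 (the limit leaves the size open), and there is a real chance that compound 4 again returns only a limit.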

Compound 4, concentration for 50% growth inhibition: > 100000 nM
Compound 4: only a limit was reported; the forecaster's own chance of this, stated with the estimate: 60%; the middle value lies on the limit itself.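

In this assay, compound 4 returns only a limit of the assay, so swapping 3-nitrophenyl for 4-bromo-2,6-difluorophenyl on the amide-type nitrogen produces no measurable growth inhibition, and the edge of the read-out now holds most of the compounds shown: the limit of > 100000 nM in this assay, at which 3 of the 4 values shown sit.

The steps linking compound 2, compound 3 and compound 4 to one another cannot be read, since both ends of each are limits. Going by these compounds alone, compound 1 remains the only compound here with a number, and its link to the new ring is only a floor: an at least 1.7-fold higher number from compound 1 to compound 4 (0.23 log units; that floor lies within the scatter).

Going by these compounds, it stays open whether any change on this nitrogen can bring a substituted phenyl ring into the readable range, for instance a phenyl ring bearing an amine or a carboxylic acid, or whether a longer chain in place of the methyl of 6-methylpyridin-2-yl would move the number of compound 1. Also open, on these data alone, is how far beyond the limit compound 2, compound 3 and compound 4 truly lie, so no order among them can be given.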